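Swapping the hydrazone aryl group for pyridin-2-yl

The compounds below may be only part of what the source reports. "The series", "measured", "known", "first", "only" and "open" are said of these compounds alone.

Two measured compounds share one core and differ only in the group on the carbon with a double bond to nitrogen. Compound 1 `NS(=O)(=O)c1ccc(Nc2nc(N/N=C/c3ccc(C(F)(F)F)cc3)nc(Nc3ccccc3)n2)cc1` gives 2640 nM in a functional assay on IGROV-1 cells (Homo sapiens) for inhibition, read by sulforhodamine B assay, with a stated time of 48 h; a higher number here means a weaker inhibitor of growth, a lower number a stronger inhibitor of growth. Compound 2 `Cc1nn(-c2ccccc2)cc1/C=N/Nc1nc(Nc2ccccc2)nc(Nc2ccc(S(N)(=O)=O)cc2)n1` gives 2590 nM in this assay. The step of a 1.0-fold lower number from compound 1 to compound 2 (0.01 log units; within the scatter) shows that exchanging 4-(trifluoromethyl)phenyl for 3-methyl-1-phenyl-1H-pyrazol-4-yl left the growth inhibition unchanged within the scatter, so compound 2 stands together with compound 1 and neither can be called the stronger inhibitor on these numbers.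

Compound 3 `NS(=O)(=O)c1ccc(Nc2nc(N/N=C/c3ccccn3)nc(Nc3ccccc3)n2)cc1` continues the same kind of exchange: pyridin-2-yl in place of 3-methyl-1-phenyl-1H-pyrazol-4-yl on a carbon with a double bond to nitrogen. Among the compounds with values here, the only step that bears on it is a 1.0-fold lower number from compound 1 to compound 2 (0.01 log units; within the scatter), which was within the scatter, and it is the single example available. On that basis compound 3 is expected to remain close to compound 2, with the step of a 1.1-fold higher number from compound 2 to compound 3 (0.03 log units; within the scatter) expected to stay within the scatter in this assay. Compound 3 is therefore estimated at 2800 nM, with a range from 1200 nM to 6500 nM.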

Compound 3, concentration for 50% growth inhibition: 790 nM
For compound 3 the middle estimate is 3.5-fold (0.55 log units) above the measured one; the whole stated range lies above it.
By their numbers in this assay, from the lowest: compound 3; then compounds 2 and 1 (each within the scatter of the next).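

The earlier pair suggested that this position might not respond to the group placed on it, but pyridin-2-yl changes that picture: in this assay it gives a 3.3-fold lower number from compound 2 to compound 3 (0.52 log units; beyond the scatter) and a 3.3-fold lower number from compound 1 to compound 3 (0.52 log units; beyond the scatter). The two larger groups, 4-(trifluoromethyl)phenyl and 3-methyl-1-phenyl-1H-pyrazol-4-yl, therefore stand together, while compound 3 is the strongest inhibitor of growth among the three, so the group on a carbon with a double bond to nitrogen can change growth inhibition, though only modestly here. No measurement is available that explains why pyridin-2-yl behaves differently from the other two groups.

The three compounds cannot separate the presence of a nitrogen in the six-membered ring from the change in the group's size, since pyridin-2-yl differs from each of the other groups in more than one feature. Unsubstituted phenyl, pyridin-3-yl and pyridin-4-yl on the same carbon would address that question, and the compounds shown leave open whether any of these groups would match or exceed compound 3.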